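Does the chloro group carry the activity of compound 3?

The compounds below may be only part of what the source reports. "The series", "measured", "known", "first", "only" and "open" are said of these compounds alone.

Compound 1, `O=c1cc(CSC(=S)N2CCCC2)oc2ccccc12`, in a functional assay on MDA-MB-435S cells (Homo sapiens) for antiproliferative activity, read by MTT assay, with a stated time of 72 h (a higher number here means a weaker inhibitor, a lower number a stronger inhibitor), gives > 30000 nM, a limit.
Compound 2, `O=c1cc(CSC(=S)N2CCCCC2)oc2ccccc12`, in this assay gives > 25000 nM, a limit.
Compound 3, `O=c1c(Cl)c(CSC(=S)N2CCOCC2)oc2ccccc12`, in this assay gives 4100 nM.

Of the compounds shown here, three have been measured. For compound 1 the value is a limit of the assay, not a number. For compound 2 the value is likewise a limit. Compound 3 is the only one of the three that gives an actual number; the other two values are limits. The step from compound 1 to compound 2, a step that the two limits leave unreadable from compound 1 to compound 2, cannot be read, since both ends are limits the limit of > 25000 nM in this assay, at which 1 of the 3 values shown sits (the limit of > 30000 nM in this assay, at which 1 of the 3 values shown sits).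

Compound 4 `O=c1cc(CSC(=S)N2CCOCC2)oc2ccccc12` has not yet been measured. It differs from compound 3 by hydrogen in place of chloro on an aromatic carbon. Among the compounds with values here, no measured step changes this position, so nothing directly gives the size of this step. Compound 1 and compound 2 also lack the chloro and both sit at limits. Compound 3 carries the chloro and gives a number. The comparison is not clean, as those compounds also differ in the group on the thiocarbonyl carbon.

In this assay compound 4 is therefore expected to be weaker than compound 3. The expected step is a 4.9-fold higher number from compound 3 to compound 4 (0.69 log units; beyond the scatter). Compound 4 is estimated at 20000 nM, ranging from 5000 nM to 60000 nM, with a real chance that only a limit is reported.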

Compound 4, half-maximal inhibitory concentration: 22200 nM
Beside the measured number, compound 4's estimate is 1.1-fold (0.05 log units) below it; the measured number falls inside the stated range.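

With the morpholin-4-yl group held the same, the chloro finally gets a clean test in this assay: hydrogen in place of chloro on this aromatic carbon, two atoms from the ring oxygen, gives a 5.4-fold higher number from compound 3 to compound 4 (0.73 log units; beyond the scatter), so the chloro does carry part of the activity seen in the pair. Without the chloro, morpholin-4-yl in place of piperidin-1-yl gives an at least 1.1-fold lower number from compound 2 to compound 4 (0.05 log units; that floor lies within the scatter), and morpholin-4-yl in place of pyrrolidin-1-yl gives an at least 1.3-fold lower number from compound 1 to compound 4 (0.13 log units; that floor lies within the scatter), so neither change of ring on the thiocarbonyl carbon shows a real gain. Those two steps start from limits of the assay and give only floors, which leaves the chloro step as the only one here with a full measured size.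

The compounds shown leave open whether chloro is needed as such, or whether fluoro, bromo or methyl on the same carbon would serve as well. They also leave open whether chloro brings a similar step with pyrrolidin-1-yl or piperidin-1-yl on the thiocarbonyl carbon, or with an open-chain amine such as diethylamino there.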